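The compounds below may be only part of what the source reports. "The series", "measured", "known", "first", "only" and "open" are said of these compounds alone.

Of the compounds shown here, three built on a shared core have been measured in a functional assay on NCI-H1299 cells (Homo sapiens) for inhibition, read by CCK-8 assay, with a stated time of 72 h, tested at 10 uM; a higher number here means more inhibition of growth at the concentration tested, a lower number less inhibition of growth. Compound 1 `CN(C)C(=O)c1cc2cnc(Nc3ccc(NC(=O)C4(C(=O)Nc5ccccc5F)CC4)cc3)nc2n1C1CCCC1` gives 89.6%. Compound 2 `CN(C)C(=O)c1cc2cnc(Nc3ccc(NC(=O)C4(C(=O)Nc5ccc(F)cc5)CC4)cc3F)nc2n1C1CCCC1` gives 82.6%. Compound 3 `CN(C)C(=O)c1cc2cnc(Nc3ccc(NC(=O)C4(C(=O)Nc5cccc(Cl)c5)CC4)cc3)nc2n1C1CCCC1` gives 84.1%. On these numbers compound 3 stands second highest of the three; its gap to compound 2 lies within the scatter, and its gap to compound 1 lies within the scatter as well. Among the measured compounds shown here, the single step between measured compounds that differ in one place, a number 5.5 percentage points lower from compound 1 to compound 3 (within the scatter), also stays within the scatter.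

Compound 4 `CN(C)C(=O)c1cc2cnc(Nc3ccc(NC(=O)C4(C(=O)Nc5ccc(Cl)cc5)CC4)cc3)nc2n1C1CCCC1` has not yet been measured. It differs from compound 3 by 4-chlorophenyl in place of 3-chlorophenyl on an amide-type nitrogen. For the measured compounds named here, no measured pair shows exactly this change. The step from compound 1 to compound 3 is the nearest guide, as it alters the same ring on the same nitrogen and its outcome lay within the scatter. Compound 2, which differs from compound 3 in two places, also sits close to compound 3 on the numbers. The step of a number 1.1 percentage points lower from compound 3 to compound 4 (within the scatter) is therefore expected to stay within the scatter, with no direction that can be told apart from noise. Compound 4 is estimated to give 83% in this assay, within a range from 70% to 93%.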

Compound 4, percent growth inhibition at one concentration: 88.6%
Compound 4: middle estimate off by 5.6 percentage points, on the low side; the range from low to high includes it.
By their numbers in this assay, from the lowest: compounds 2, 3, 4 and 1 (each within the scatter of the next).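

In this assay, among the compounds shown here, putting 4-chlorophenyl in place of 3-chlorophenyl on the amide-type nitrogen gives a number 4.5 percentage points higher from compound 3 to compound 4 (within the scatter), so the first direct comparison of these two chlorophenyl groups at this position does not separate them. The step of a number 1 percentage points lower from compound 1 to compound 4 (within the scatter) adds a second reading with 4-chlorophenyl in place of 2-fluorophenyl, and together with the earlier step between compound 1 and compound 3, it shows that these three substituted phenyl groups on this nitrogen cannot be told apart by this read-out at the single concentration tested. No measurement is available that would explain these numbers or the small differences among them.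

The compounds shown leave open whether this tolerance extends beyond halogen-bearing phenyl groups, for instance to a 4-methoxyphenyl, a 4-aminophenyl or a saturated cyclohexyl ring on the same nitrogen. They also leave open whether compound 1, compound 3 and compound 4 would separate if followed across a series of lower concentrations rather than read at one.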